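A few compounds are considered here, and "the series" means these few. Any claim that something is new, unique, unknown or untested is made for them only; others in the source may bear on it.

Of the compounds shown here, three have been measured in an ADME assay on liver for metabolic stability, with Liver microsome (Rattus norvegicus) as the target, read by LC-MS, using microsomes, with a stated time of 5 h; on this read-out lower numbers stand for slow clearance and higher numbers for fast clearance. Compound 1 `O[C@H](c1ccccn1)[C@]1(c2ccc(C(F)(F)F)cc2)C[C@@H](O)C1` gives 50 mL/min/kg in this assay. Compound 2 `O[C@]1(c2ccccn2)CC[C@H](c2ccc(C(F)(F)F)cc2)C1` gives 1430 mL/min/kg in this assay. Compound 3 `O[C@H](c1ccccn1)[C@@]1(c2ccc(Cl)c(Cl)c2)CCO1` gives 1000 mL/min/kg in this assay, which places compound 3 second highest of the three numbers: its nearest neighbour is compound 2, whose value lies within the scatter of that of compound 3, while compound 1 sits far lower, beyond the scatter. Going by the values given here, none of these three pairs differs in only one place, so no single step between measured compounds is available.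

The step of interest leads from compound 3 to compound 4 `O[C@H](c1ccccn1)[C@]1(c2ccc(Cl)c(Cl)c2)CCO1`, which has not yet been measured in this assay. The change is the two compounds have the same atoms and bonds and differ only in configuration as drawn: 1 of 2 stereo elements differ; a stereocentre at a saturated ring carbon is drawn S in compound 3 and R in compound 4. Nothing in the measured set shows what such an inversion at the saturated ring carbon does to clearance in this assay. Among the compounds with values here, no pair differing only in configuration has been measured. The expectation for the step of a 1.3-fold lower number from compound 3 to compound 4 (0.10 log units; within the scatter) is therefore a small one, in no firm direction, most likely staying within the scatter of compound 3. On that basis compound 4 is estimated to give 800 mL/min/kg in this assay, with a likely range from 250 mL/min/kg to 2500 mL/min/kg.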

Compound 4, clearance: 50 mL/min/kg
Beside the measured number, compound 4's estimate is 16-fold (1.20 log units) above it; measured number below the stated range.
By their numbers in this assay, from the lowest: compounds 1 and 4 (each within the scatter of the next); then compounds 3 and 2 (each within the scatter of the next).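

In this assay, going by these compounds alone, the inversion at the saturated ring carbon gives a 20-fold lower number from compound 3 to compound 4 (1.30 log units; beyond the scatter), a large step and the first reading of what configuration alone can do here. The earlier compounds shown here held no pair of this kind, so only now does this position prove sensitive to how it is drawn, with the same atoms and bonds on both sides of the step. The whole of the step can be tied to that single inversion because nothing else changes between the two compounds: the fact that compounds 3 and 4 differ only in the configuration as drawn.

The compounds shown hold only this one such pair, on one shared core, so they do not tell whether the inversion would count for as much on another core, or what the other stereo element would do if it alone were inverted. Nor do they tell how clearance would respond in either configuration if a group such as an amine or a carboxylic acid stood on the shared core.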